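Compound 3: an untested swap after two limits

This account rests on a few compounds, and the source may have more. Where it says the series, first, only, none or still open, it means among the compounds named here.

Compound 1 `COc1cc(C2=C(c3cc(C)c(OC)c(C)c3)C(O)CC2=O)cc(OC)c1OC`: > 100 ug/mL, a limit
Compound 2 `COc1cc(C2=C(c3cc(C)c(OC)c(C)c3)C(OC(C)=O)CC2=O)cc(OC)c1OC`: > 100 ug/mL, a limit

In an ADME assay on KB cells (Homo sapiens) for cytotoxicity, read by MTT assay, with a stated time of 72 h (on this read-out lower numbers stand for stronger inhibition and higher numbers for weaker inhibition), compound 2 reads > 100 ug/mL, which is a limit and not a number. That is its whole standing, and the limit of > 100 ug/mL in this assay, at which 2 of the 2 values shown sit, sums up what has been measured so far. Compound 3 `COc1ccc(C2=C(c3cc(OC)c(OC)c(OC)c3)C(=O)CC2OC(C)=O)cc1NC=O` carries a new group: 3-(formylamino)-4-methoxyphenyl in place of 4-methoxy-3,5-dimethylphenyl on a double-bonded ring carbon. Within the data shown here, the only measured step, a step that the two limits leave unreadable from compound 1 to compound 2, concerns an acetyl on an oxygen, not this group, so it gives no size to carry over. With no readable step to go on, the expectation rests on the limit of > 100 ug/mL in this assay, at which 2 of the 2 values shown sit, and remains loose. Any readable result could only lie toward stronger inhibition. The expected step is an at least 3.3-fold lower number from compound 2 to compound 3 (0.52 log units; beyond the scatter), a modest one with wide uncertainty. For compound 3 the estimated value is 30 ug/mL, with an expected range from 2 ug/mL to 100 ug/mL.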

Compound 3, half-maximal inhibitory concentration: 8 ug/mL
Beside the measured number, compound 3's estimate is 3.8-fold (0.57 log units) above it; the range from low to high includes it.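

In this assay, among these compounds, placing 3-(formylamino)-4-methoxyphenyl on the double-bonded ring carbon in place of 4-methoxy-3,5-dimethylphenyl gives the first readable step: an at least 12-fold lower number from compound 2 to compound 3 (1.09 log units; beyond the scatter). This shows that the number responds to a change at this position, something the acetyl change could not show, as the step between its two limits cannot be read. The value of compound 2, > 100 ug/mL, is a limit and not a number, and the limit remains common among the compounds shown: the limit of > 100 ug/mL in this assay, at which 2 of the 3 values shown sit.

One swap cannot show which part of the new group matters, the formylamino group or the shifted methoxy group. Going by these compounds, it also remains open how a free amine or an acetylamino group would read at the same place, and whether the size of the step would hold with a hydroxyl in place of the acetoxy group.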